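Halogen swap on a spirooxindole series: chloro to bromo

A few compounds are considered here, and "the series" means these few. Any claim that something is new, unique, unknown or untested is made for them only; others in the source may bear on it.

Compound 1 `COc1ccc([C@@H]2[C@@H](c3ccccc3)N[C@]3(C(=O)Nc4ccc(Cl)cc43)[C@]23CNc2c(cccc2[N+](=O)[O-])C3=O)cc1` and compound 2 `COc1ccc([C@@H]2[C@@H](c3ccccc3)N[C@]3(C(=O)Nc4ccc(Br)cc43)[C@]23CNc2c(cccc2[N+](=O)[O-])C3=O)cc1` share one core; in a functional assay on HeLa cells (Homo sapiens) for cytotoxicity, read by MTT assay, with a stated time of 72 h (a lower number here means a stronger inhibitor, a higher number a weaker inhibitor), compound 1 gives 16000 nM and compound 2 gives 19000 nM. The change between them is bromo in place of chloro on an aromatic carbon, and its step is a 1.2-fold higher number from compound 1 to compound 2 (0.07 log units; within the scatter). Compound 3 `O=C1c2cccc([N+](=O)[O-])c2NC[C@@]12[C@H](c1ccc(Cl)cc1)[C@@H](c1ccccc1)N[C@]21C(=O)Nc2ccc(F)cc21` rests on a different core; the difference between the two cores is not broken down here. In this assay compound 3 gives 25000 nM, a value within the scatter of compound 1 and compound 2. Compound 4 `O=C1c2cccc([N+](=O)[O-])c2NC[C@@]12[C@H](c1ccc(Br)cc1)[C@@H](c1ccccc1)N[C@]21C(=O)Nc2ccc(F)cc21` is not yet measured in this assay. From compound 3 to compound 4 the change is bromo in place of chloro on an aromatic carbon. This is the same kind of change as from compound 1 to compound 2, but the surroundings differ: in the first pair the ring is part of a fused or bridged system of five rings, meta to a fused ring and para to a fused ring, whereas here the ring carries the halogen para to a large group. Beside the earlier step of a 1.2-fold higher number from compound 1 to compound 2 (0.07 log units; within the scatter), the expected step is a 1.1-fold higher number from compound 3 to compound 4 (0.05 log units; within the scatter), resting on compound 3 at 25000 nM and the near-flat step between compound 1 and compound 2. Compound 4 is estimated at 28000 nM, between 14000 nM and 56000 nM.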

Compound 4, half-maximal inhibitory concentration: 26000 nM
For compound 4 the middle estimate is 1.1-fold (0.03 log units) above the measured one; low and high end bracket the measured number.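

In this assay, bromo in place of chloro on an aromatic carbon para to a large group gives a 1.0-fold higher number from compound 3 to compound 4 (0.02 log units; within the scatter). Set beside the earlier step, the change carries over from one core to the other in these two pairs, and the two steps cannot be told apart: the same change on two cores in this assay, a 1.2-fold higher number (0.07 log units; within the scatter) from compound 1 to compound 2 and a 1.0-fold higher number (0.02 log units; within the scatter) from compound 3 to compound 4, 1.1-fold (0.06 log units) apart, within the scatter of two such steps This does not show that the swap makes no difference on every core or at every place, since the halogen sits on a different ring in each pair, and the result rests on four compounds in a single cell assay.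

The compounds shown replace one halogen with another and so leave open what a group of a different kind, such as an amine or a carboxylic acid, would give at the same place on the phenyl ring. Also open, on these data alone, is whether the flat step holds on other cores or in readouts other than this assay.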